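Pyrrolyl in Place of Nitrophenyl: Expected Brine Shrimp Toxicity

This account rests on a few compounds, and the source may have more. Where it says the series, first, only, none or still open, it means among the compounds named here.

Three compounds share one core and differ only in the group on a double-bonded chain carbon bound to a double-bonded chain carbon. In an ADME assay on the whole organism for cytotoxicity, with Artemia salina as the target, with a stated time of 24 h (a higher number here means that more compound is needed for the effect, a lower number that less compound is needed), compound 1 `COc1ccc(/C=C/C(=O)c2ccccc2NC(=O)NS(=O)(=O)c2ccc(C)cc2)c(OC)c1` gives 16 ug/mL, compound 2 `COc1cc(/C=C/C(=O)c2ccccc2NC(=O)NS(=O)(=O)c2ccc(C)cc2)ccc1O` gives 17.8 ug/mL, and compound 3 `Cc1ccc(S(=O)(=O)NC(=O)Nc2ccccc2C(=O)/C=C/c2ccccc2[N+](=O)[O-])cc1` gives 40.1 ug/mL, the highest number of the three. The steps of a 2.5-fold higher number from compound 1 to compound 3 (0.40 log units; beyond the scatter) and a 2.3-fold higher number from compound 2 to compound 3 (0.35 log units; beyond the scatter) both lie beyond the scatter. Compound 4 `Cc1ccc(S(=O)(=O)NC(=O)Nc2ccccc2C(=O)/C=C/c2ccc[nH]2)cc1` arises from compound 3 by 1H-pyrrol-2-yl in place of 2-nitrophenyl on a double-bonded chain carbon bound to a double-bonded chain carbon. Going by the values given here, no measured step exchanges a six-membered ring for a five-membered one, so a direct precedent is lacking; the two steps into compound 3 show only that the group at this place can shift the number modestly. Compound 4 is therefore expected to show a 1.6-fold lower number from compound 3 to compound 4 (0.21 log units; within the scatter). The estimate for compound 4 is 25 ug/mL, with a range of 10 ug/mL to 60 ug/mL.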

Compound 4, concentration for half-maximal effect: 32.1 ug/mL
Beside the measured number, compound 4's estimate is 1.3-fold (0.11 log units) below it, within the range that was stated.
By their numbers in this assay, from the lowest: compounds 1, 2, 4 and 3 (each within the scatter of the next, the first and the last beyond it).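

Exchanging the six-membered aromatic ring for a five-membered one that carries a hydrogen-bond donor shifts the result little at this place, with a 1.2-fold lower number from compound 3 to compound 4 (0.10 log units; within the scatter). Going by these compounds alone, compound 4 is also the only compound here that no step separates from the others beyond the scatter, with a 1.8-fold higher number from compound 2 to compound 4 (0.26 log units; within the scatter) and a 2.0-fold higher number from compound 1 to compound 4 (0.30 log units; within the scatter), although compound 3 stands beyond the scatter from both compound 1 and compound 2. Nothing shown accounts for this result. Open, as far as these compounds go, is whether a furan-2-yl, a thiophen-2-yl or a 1-methylpyrrol-2-yl group at this place would fall within the same span of numbers.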